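Compound 2 to compound 3: one ring group exchanged

The compounds below may be only part of what the source reports. "The series", "measured", "known", "first", "only" and "open" are said of these compounds alone.

- Compound 1 `COc1cc(/C=C2\CN(C)C/C(=C\c3cccnc3)C2=O)cc(OC)c1`: 18400 nM
- Compound 2 `CN1C/C(=C\c2cccnc2)C(=O)/C(=C/c2ccc(F)cc2Br)C1`: 14400 nM

In an ADME assay on L02 cells (Homo sapiens) for cytotoxicity, read by MTT assay, with a stated time of 24 h (a higher number here means a weaker inhibitor, a lower number a stronger inhibitor), compound 2 gives 14400 nM and compound 1 gives 18400 nM. These two numbers lie within the usual scatter of each other, so neither stands apart.

Compound 3 `CN1C/C(=C\c2ccc(C#N)cc2)C(=O)/C(=C/c2cccnc2)C1` has not yet been measured. It carries 4-cyanophenyl in place of 2-bromo-4-fluorophenyl on a double-bonded chain carbon bound to a double-bonded ring carbon.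

Within the data shown here, no measured pair shows this exchange directly, so the only guide is how close compound 1 and compound 2 sit. No step beyond the scatter is expected in this assay, in either direction. The estimated change is a 1.0-fold higher number from compound 2 to compound 3 (0.02 log units; within the scatter). For compound 3 the estimated value is 15000 nM, with an expected range of 6000 nM to 38000 nM.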

Compound 3, half-maximal inhibitory concentration: > 20000 nM
Compound 3 ended at the assay's limit; the forecaster's own chance of this, stated with the estimate: 5%; middle value at least 1.3-fold (0.12 log units) from the limit.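

In this assay, among these compounds, putting 4-cyanophenyl in place of 2-bromo-4-fluorophenyl on a double-bonded chain carbon bound to a double-bonded ring carbon gives an at least 1.3-fold higher number from compound 2 to compound 3 (0.14 log units; that floor lies within the scatter), the first step at this position that links two measured compounds. For compound 3 the value > 20000 nM is a limit of the assay and not a number. The exchange therefore yields no stronger inhibitor, but the step is only a floor and its true size cannot be read, as the measurement stops here: the limit of > 20000 nM in this assay, at which 1 of the 3 values shown sits.

The compounds shown do not separate the loss of the bromine and the fluorine from the arrival of the nitrile, nor do they say how far compound 3 lies past the limit. Going by these compounds, how a phenyl ring carrying an amine or a carboxylic acid would read at this place in this assay also stays open.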